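The compounds below may be only part of what the source reports. "The series", "measured", "known", "first", "only" and "open" are said of these compounds alone.

The measured compounds and their results:

compound 1, `Nc1ccccc1NC(=O)c1ccc(CSC(=S)N2CCN(c3ccc(Cl)cc3)CC2)cc1`, 15%
compound 2, `CC1CCCCN1C(=S)SCc1ccc(C(=O)Nc2ccccc2N)cc1`, 64.4%
compound 3, `Nc1ccccc1NC(=O)c1ccc(CSC(=S)N2CCc3ccc([N+](=O)[O-])cc32)cc1`, 30.6%

All three were tested in a functional assay on MGC-803 cells (Homo sapiens) for antiproliferative activity, read by CCK-8 assay, with a stated time of 72 h, tested at 2 uM; on this read-out higher numbers stand for a stronger effect at the one concentration tested and lower numbers for a weaker effect. Compound 1 stands at the bottom of the three numbers. Its nearest neighbour is compound 3, which gives 30.6%, a gap beyond the usual scatter of this measurement, and compound 2 gives 64.4%, far above both. No single-point comparison between these measured compounds is available, so the values stand on their own.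

The next compound to be measured is compound 4, `Nc1ccccc1NC(=O)c1ccc(CSC(=S)N2CCN(c3ccncc3)CC2)cc1`. It differs from compound 1 in one place: pyridin-4-yl in place of 4-chlorophenyl on an amine nitrogen in a ring. Within the data shown here, the only reference is compound 1 at 15%, and nothing measured here shows how this exchange on the ring nitrogen moves the read-out. A modest step is expected, more likely upward than downward, but possibly none beyond the scatter. Compound 4 is expected to give 22%, within a range from 8% to 42%. The expected step is a number 7 percentage points higher from compound 1 to compound 4 (within the scatter).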

Compound 4, a percentage reported as inhibition, at one concentration (the size of the read-out at that concentration, not a potency): 64.8%
Estimate against measurement, compound 4: 42.8 percentage points below, outside the stated range (above it).
By their numbers in this assay, from the lowest: compound 1; then compound 3; then compounds 2 and 4 (each within the scatter of the next).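

In this assay, the group on this amine nitrogen of the six-membered non-aromatic ring proves to matter greatly: with pyridin-4-yl in place of 4-chlorophenyl, the read-out is a number 49.8 percentage points higher from compound 1 to compound 4 (beyond the scatter). Among these compounds, until this pair, no two measured compounds differed in one place, so the earlier values could not show that this position responds to a change at all. The exchange removes the chlorine and puts a nitrogen into the aromatic ring, and nothing available explains the size of the step.

The compounds shown cannot tell whether losing the chlorine or gaining the ring nitrogen accounts for the step. A plain phenyl group at the same place would help separate the two, and pyridin-3-yl would test where the ring nitrogen sits.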